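From methyl to chloro: an expected small step

The source may hold more compounds than are shown below. What is called first, only, known or untested is meant among the compounds shown, and "the series" means these compounds.

Measured in a functional assay on DU-145 cells (Homo sapiens) for antiproliferative activity, read by MTT assay, with a stated time of 24 h; on this read-out higher numbers stand for weaker inhibition and lower numbers for stronger inhibition:
compound 1 `COc1ccc(-c2cc(/C=C/C(=O)c3ccc(C)cc3)nc3cc(-c4ccccc4)nn23)cc1OC` gives 26800 nM
compound 2 `COc1cc(-c2cc(/C=C/C(=O)c3ccc(C)cc3)nc3cc(-c4ccccc4)nn23)cc(OC)c1OC` gives 27100 nM
compound 3 `COc1cc(-c2cc(/C=C/C(=O)c3ccccc3)nc3cc(-c4ccccc4)nn23)cc(OC)c1OC` gives 34300 nM

Among the measured compounds shown here, compound 1 holds the lowest of the three numbers, but the steps of a 1.0-fold higher number from compound 1 to compound 2 (0.00 log units; within the scatter) and a 1.3-fold higher number from compound 2 to compound 3 (0.10 log units; within the scatter) both stay inside the scatter, so no compound separates from the others. Compound 4 `COc1ccc(-c2cc(/C=C/C(=O)c3ccc(Cl)cc3)nc3cc(-c4ccccc4)nn23)cc1OC` differs from compound 1 by chloro in place of methyl on an aromatic carbon. For the measured compounds named here, the only measured step touching that position, a 1.3-fold higher number from compound 2 to compound 3 (0.10 log units; within the scatter), was small, and no measured pair carries chloro there. Compound 4 is therefore expected to give 25000 nM in this assay, with a range from 10000 nM to 60000 nM. The expected step of a 1.1-fold lower number from compound 1 to compound 4 (0.03 log units; within the scatter) is estimated to stay within the scatter.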

Compound 4, half-maximal inhibitory concentration: 21300 nM
Estimate against measurement, compound 4: 1.2-fold (0.07 log units) above, within the range that was stated.
By their numbers in this assay, from the lowest: compounds 4, 1, 2 and 3 (each within the scatter of the next).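

In this assay the change from 4-methylphenyl to 4-chlorophenyl gives a 1.3-fold lower number from compound 1 to compound 4 (0.10 log units; within the scatter) and so leaves compound 4 level with compound 1. Until now this position had carried only methyl and hydrogen, and chloro is the first atom other than carbon or hydrogen shown there, yet the read-out still does not separate. Nothing available explains this result. Going by these compounds, whether an amine or a carboxylic acid on this ring would also stay within the scatter remains open. So does whether any group at this position can move the number clearly away from that of compound 1.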